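Amino in place of chloro on compound 1

The source may report more compounds than this note shows. Statements on the series, on what has been measured and on what is new or still open speak of the compounds shown alone.

Measured in a functional assay (aorta) for inhibition, with Rattus norvegicus as the target, with a stated time of 8 days; a higher number here means a weaker inhibitor, a lower number a stronger inhibitor
- compound 1 `Cc1nsc(-c2ccc(N3CCN(c4cccc(Cl)c4)CC3)nn2)n1` gives 0.6 nM
- compound 2 `Cc1nsc(-c2ccc(N3CCN(c4cccc(C(F)(F)F)c4)CC3)nc2)n1` gives 5 nM
- compound 3 `Nc1nsc(-c2ccc(N3CCN(c4cccc(C(F)(F)F)c4)CC3)nn2)n1` gives 20 nM

Compound 1 holds the lowest of these three numbers, and compound 2 and compound 3 both lie above it, beyond the scatter. Compound 4 `Cc1nsc(-c2ccc(N3CCN(c4cccc(N)c4)CC3)nn2)n1` is compound 1 with amino in place of chloro on an aromatic carbon, meta to a large group (amino in place of chloro on an aromatic carbon). For the measured compounds named here, no measured pair shows this change alone, so the expectation is loose. Compound 3 also carries an amino group, at another place, and gives 20 nM, which suggests a weaker inhibitor in this assay rather than a stronger one. The expected change is a rise beyond the scatter, an estimated step of a 13-fold higher number from compound 1 to compound 4 (1.12 log units; beyond the scatter). For compound 4 the estimated value is 8 nM, with an expected range from 1.5 nM to 40 nM.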

Compound 4, half-maximal inhibitory concentration: > 100 nM
Compound 4: only a limit was reported; the forecaster's own chance of this, stated with the estimate: 3%; middle value at least 12-fold (1.09 log units) from the limit.
By their numbers in this assay, from the lowest: compound 1; then compound 2; then compound 3. At a limit, above all of these: compound 4.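

In this assay, for the compounds shown here, the change from 3-chlorophenyl to 3-aminophenyl gives the first comparison at this position that differs in one place only, and it is large: an at least 160-fold higher number from compound 1 to compound 4 (2.22 log units; beyond the scatter). The value for compound 4 is a limit and not a number: the limit of > 100 nM in this assay, at which 1 of the 4 values shown sits. Exchanging a single heavy atom at this place on the core of compound 1 is therefore enough to move the number far upward.

The compounds shown leave open whether other groups at this place, such as a hydroxyl, a methoxy or a nitrile, would follow amino or chloro. With two groups compared here, no trend across groups can be drawn.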